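The source may report more compounds than this note shows. Statements on the series, on what has been measured and on what is new or still open speak of the compounds shown alone.

Measured compounds:
compound 1 `CC(C)Oc1cncc(C2=CC3CC(C2)CN(C)C3)c1` with 3.3%
compound 2 `C1=C(c2cccnc2)C[C@H]2CNC[C@@H]1C2` with 129%

Of the compounds shown here, two have numbers so far. In an in vitro functional assay on SH-EP1 cells for agonist activity at Neuronal acetylcholine receptor; alpha4/beta2 (Homo sapiens), read by FLIPR and calcium flux (on this read-out lower numbers stand for smaller maximal responses and higher numbers for larger maximal responses), compound 1 gives 3.3%. Compound 2 gives 129% in this assay, and it stands highest of the two, with compound 1 sitting far lower, a gap well beyond the scatter.

The account now turns to compound 3 `C1=C(c2cccnc2)C[C@@H]2CNC[C@H]1C2`, which is yet to be measured in this assay. Its relation to compound 2 is the two compounds have the same atoms and bonds and differ only in configuration as drawn: 2 of 2 stereo elements differ (all stereocentres are inverted: mirror images); a stereocentre at a saturated ring carbon is drawn S in compound 2 and R in compound 3; a stereocentre at a saturated ring carbon is drawn R in compound 2 and S in compound 3.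

Going by the values given here, no step between measured compounds is known for a change of this kind, so the size of the step can only be guessed. Because compound 2 gives 129%, the mirror image is expected to sit lower, with a fairly large downward step, though the spread on this expectation is wide. For compound 3 the expected value in this assay is 75%, within 10% to 130%, which means an expected step of a number 54 percentage points lower from compound 2 to compound 3 (beyond the scatter).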

Compound 3, largest response reached (reported as percent of maximum), in percent of the reference or control that the assay uses: 131%
Beside the measured number, compound 3's estimate is 56 percentage points below it; measured number outside the range, above it.
By their numbers in this assay, from the lowest: compound 1; then compounds 2 and 3 (each within the scatter of the next).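

In this assay, going by these compounds alone, the first step that changes configuration alone amounts to a number 2 percentage points higher from compound 2 to compound 3 (within the scatter). This pair isolates that change, which no earlier comparison could do: the fact that compounds 2 and 3 differ only in the configuration as drawn. For these two compounds, then, inverting both stereocentres leaves the largest response without a separation that can be read, so this read-out does not distinguish the two mirror images.

The compounds shown leave open whether the same holds for a mirror-image pair carrying a further group on the shared core, such as a nitrile or an ethoxy group. Compound 1 cannot settle this, as it differs from compound 2 in more than one place and no mirror image of it is shown here, and the largest response alone says nothing about the concentrations at which these responses are reached.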